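A few compounds are considered here, and "the series" means these few. Any claim that something is new, unique, unknown or untested is made for them only; others in the source may bear on it.

Compounds measured so far:
compound 1 `COc1ccc(Oc2ccccc2-c2ccsc2S(=O)(=O)N2CCN(C(=O)Nc3cccc([N+](=O)[O-])c3)CC2)cc1OC` — 18%
compound 2 `COc1ccc(Oc2ccccc2-c2ccsc2S(=O)(=O)N2CCN(C(=S)Nc3cc(C(F)(F)F)cc(C(F)(F)F)c3)CC2)cc1OC` — 25%
compound 3 `O=S(=O)(c1sccc1-c1ccccc1Oc1ccc(O)c(O)c1)N1CCN(C(=S)Nc2cc(C(F)(F)F)cc(C(F)(F)F)c2)CC1` — 20%

In an assay for binding affinity to Apoptosis regulator Bcl-2 (Homo sapiens), read by fluorescence polarization, with stated times of 30 min and 20 min, tested at 100 uM (a lower number here means less inhibition, a higher number more inhibition at the concentration tested (going by the name of the read-out)), compound 1 gives 18%, compound 2 gives 25% and compound 3 gives 20%. Compound 3 sits between the other two, with compound 1 and compound 2 each within the scatter of it. Among the compounds with values here, the only single-point step, a number 5 percentage points lower from compound 2 to compound 3 (within the scatter), lies within the scatter.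

Compound 4 `O=[N+]([O-])c1ccc(Oc2ccc(O)c(O)c2)c(-c2ccsc2S(=O)(=O)N2CCN(C(=S)Nc3cc(C(F)(F)F)cc(C(F)(F)F)c3)CC2)c1` differs from compound 3 by nitro in place of hydrogen on an aromatic carbon, on an aromatic carbon of a six-membered aromatic ring of carbon only, para to the 3,4-dihydroxyphenoxy group. Within the data shown here, no measured step touches this position, so nothing here points to a change beyond the scatter. Compound 4 is therefore expected near compound 3, at 20% (range 8% to 32%), an estimated step of no change at the digits printed from compound 3 to compound 4 (within the scatter).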

Compound 4, a percentage reported as inhibition, at one concentration (the size of the read-out at that concentration, not a potency): 12%
Beside the measured number, compound 4's estimate is 8 percentage points above it; low and high end bracket the measured number.
By their numbers in this assay, from the lowest: compounds 4, 1, 3 and 2 (each within the scatter of the next, the first and the last beyond it).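

Nitro in place of hydrogen on the aromatic carbon para to the 3,4-dihydroxyphenoxy group gives a number 8 percentage points lower from compound 3 to compound 4 (within the scatter) in this assay, the first reading at this position. At this single concentration, the position takes the added nitro without a change beyond the scatter. Nothing measured here speaks to what lies behind this reading.

From the compounds shown here alone, whether an amine, a carboxylic acid or a methoxy group on this same aromatic carbon would read differently remains open. So does the effect of nitro here alongside the 3,4-dimethoxyphenyl group.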